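Pyridin-4-yl in place of isopropyl: an untested step

The source may hold more compounds than are shown below. What is called first, only, known or untested is meant among the compounds shown, and "the series" means these compounds.

Compound 1 `Cc1cccc2sc(NC(=O)CCN3CCN(C(C)C)CC3)nc12`: 1800 nM
Compound 2 `Cc1cccc2sc(NC(=O)CCN3CCN(C4CCN(C)CC4)CC3)nc12`: 3600 nM
Compound 3 `Cc1ccccc1N1CCN(CCC(=O)Nc2nc3c(C)cccc3s2)CC1`: > 1000 nM (a limit of the assay, not a number)

In an assay on membranes from liver for displacement of a labelled ligand from Sigma intracellular receptor 2 (Rattus norvegicus), read by scintillation counting, with a stated time of 120 min (a lower number here means a stronger inhibitor, a higher number a weaker inhibitor), compound 1 gives 1800 nM, the lowest of the two numbers shown. Compound 2 gives 3600 nM, a step of a 2.0-fold higher number from compound 1 to compound 2 (0.30 log units; within the scatter). For compound 3 the value > 1000 nM is a limit of the assay and not a number, (the limit of > 1000 nM in this assay, at which 1 of the 3 values shown sits). Compound 4 `Cc1cccc2sc(NC(=O)CCN3CCN(c4ccncc4)CC3)nc12` differs from compound 1 thus: pyridin-4-yl in place of isopropyl on an amine nitrogen in a ring. The step that the limit leaves unreadable from compound 1 to compound 3 also puts an aromatic group in that place and so bears most on it, yet it cannot be read. The step of a 2.0-fold higher number from compound 1 to compound 2 (0.30 log units; within the scatter) shows a ring there costing little. A somewhat higher number is expected for compound 4, a 2.2-fold higher number from compound 1 to compound 4 (0.35 log units; beyond the scatter), with a fair chance that only a limit is reported. The estimate for compound 4 is 4000 nM, between 1500 nM and 12000 nM.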

Compound 4, inhibition constant: 1700 nM
Estimate against measurement, compound 4: 2.4-fold (0.37 log units) above; measured number inside the range.
By their numbers in this assay, from the lowest: compounds 4, 1 and 2 (each within the scatter of the next, the first and the last beyond it).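

Compound 4 shows that an aromatic ring can sit on this amine nitrogen without moving the number beyond the scatter, which the unreadable compound 3 could not show: a 1.1-fold lower number from compound 1 to compound 4 (0.02 log units; within the scatter). For the compounds shown here, the pyridin-4-yl group also gives the first step at this position that lies beyond the scatter, though a modest one: a 2.1-fold lower number from compound 2 to compound 4 (0.33 log units; beyond the scatter). The value of compound 3 is a limit, so its steps cannot be read: the limit of > 1000 nM in this assay, at which 1 of the 4 values shown sits.

On these data alone, whether a plain phenyl or a pyridin-3-yl group would behave like pyridin-4-yl remains open. So does the effect of a carboxylic acid or a longer chain at this nitrogen.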